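This account rests on a few compounds, and the source may have more. Where it says the series, first, only, none or still open, it means among the compounds named here.

The shared core of these compounds carries a carbonyl-linked group on the aromatic ring, and only that group varies. Compound 1 `CC(=O)Oc1ccc2c(c1)C(n1ccccc1=O)=CC(C)(C)O2` gives 5.6 in a functional assay (aorta) with Rattus norvegicus as the target; a lower number here means a less potent compound, a higher number a more potent compound, by a factor of ten per unit of this negative logarithm. Compound 2 `CC1(C)C=C(n2ccccc2=O)c2cc(OC(=O)Nc3ccccc3F)ccc2O1` gives 5.38 in this assay, and compound 3 `CC1(C)C=C(n2ccccc2=O)c2cc(OC(=O)Nc3ccccc3C(F)(F)F)ccc2O1` gives 5.58 in this assay. All three numbers lie close together: the change is a number 0.22 log units lower from compound 1 to compound 2 (within the scatter), then a number 0.02 log units lower from compound 1 to compound 3 (within the scatter), and a number 0.20 log units higher from compound 2 to compound 3 (within the scatter). So compound 3 stands with the others inside the usual spread, neither clearly stronger nor weaker than either.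

Compound 4 `CC1(C)C=C(n2ccccc2=O)c2cc(OC(=O)Nc3ccc(C(F)(F)F)cc3)ccc2O1` has not yet been measured. It differs from compound 3 in one place: 4-(trifluoromethyl)phenyl in place of 2-(trifluoromethyl)phenyl on an amide-type nitrogen. The same atoms are present, joined differently, so the trifluoromethyl group simply moves to another position on the phenyl ring.

Among the measured compounds shown here, none of the measured steps moves a trifluoromethyl group around a ring, so nothing directly bears on this change. What the three steps do show is that exchanging the whole group on the carbonyl carbon, from methyl to (2-fluorophenyl)amino or (2-(trifluoromethyl)phenyl)amino, left this assay within the scatter each time. A smaller rearrangement is therefore expected to do no more, and the step of a number 0.02 log units higher from compound 3 to compound 4 (within the scatter) is estimated to fall within the scatter. Compound 4 is expected to give about 5.6 in this assay, with a likely range from 5.1 to 6.1.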

Compound 4, logarithm of the reciprocal of the active concentration, log(1/C): 5.1
Estimate against measurement, compound 4: 0.50 log units above, within the range that was stated.
By their numbers in this assay, from the lowest: compounds 4, 2, 3 and 1 (each within the scatter of the next, the first and the last beyond it).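

Moving the trifluoromethyl group, with no atom gained or lost, is enough to carry a step past the scatter in this assay: the move gives a number 0.48 log units lower from compound 3 to compound 4 (beyond the scatter). So where this group sits on the phenyl ring matters here, even though the earlier exchanges of the whole group on the carbonyl carbon stayed within the scatter, and the (4-(trifluoromethyl)phenyl)amino group is the first of them to leave it, with a number 0.50 log units lower from compound 1 to compound 4 (beyond the scatter). The picture has a limit, however: the step from the 2-fluorophenyl group is a number 0.28 log units lower from compound 2 to compound 4 (within the scatter), so compound 4 cannot be told apart from compound 2, and the effect of the move shows only against compound 3 and compound 1.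

Nothing measured on these compounds explains why the position of the trifluoromethyl group should matter in this way. On these data alone, it also remains open whether the same step appears with a different group on the phenyl ring, such as a chlorine atom, a methoxy group or a nitrile, moved in the same way in place of the trifluoromethyl group.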